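A methoxy group added to compound 3

The source may hold more compounds than are shown below. What is called first, only, known or untested is meant among the compounds shown, and "the series" means these compounds.

Values from a functional assay on B16 cells (Mus musculus) for inhibition, with a stated time of 72 h; a lower number here means a stronger inhibitor, a higher number a weaker inhibitor:
Compound 1 (`Cc1ccc(CN2CCNC2=S)cc1`) gives 4800 nM
Compound 2 (`COc1ccc(CN2CCNC2=S)cc1`) gives > 10000 nM as a limit
Compound 3 (`S=C1NCCCN1Cc1ccccc1`) gives > 10000 nM as a limit

Compound 3 has no exact number, only a limit (the limit of > 10000 nM in this assay, at which 2 of the 3 values shown sit) to start from. Compound 4 (`COc1ccc(CN2CCCNC2=S)cc1`) differs from it in one place (methoxy in place of hydrogen on an aromatic carbon), with methoxy in place of hydrogen on an aromatic carbon.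

For the measured compounds named here, one measured step bears on this change. It is an at least 2.0-fold higher number from compound 1 to compound 2 (0.31 log units; beyond the scatter), where methoxy took the place of methyl on an aromatic carbon, and it shows weaker inhibition beyond the scatter. That step began from methyl rather than hydrogen and sits on the core of compound 1, so it is only a loose guide. It gives no sign of a gain from methoxy, so no clear strengthening is expected. The expected step is a step that the limit leaves unreadable from compound 3 to compound 4 in this assay, with compound 4 likely to remain weak. For compound 4 the estimated value is 12000 nM, with an expected range from 5000 nM to 30000 nM and a good chance that only a limit is reported.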

Compound 4, half-maximal inhibitory concentration: 6100 nM
Beside the measured number, compound 4's estimate is 2.0-fold (0.29 log units) above it; the measured number falls inside the stated range.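

In this assay, methoxy in place of hydrogen on an aromatic carbon gives an at least 1.6-fold lower number from compound 3 to compound 4 (0.21 log units; that floor lies within the scatter). That floor lies within the usual scatter, so the step alone does not establish stronger inhibition, although the true change could be larger. For the compounds shown here, what is new is that a methoxy group at this place, para to a group of 8 heavy atoms, can sit on a compound with an exact measured value, whereas the only earlier methoxy compound, compound 2, gave just a limit.

Going by these compounds, the true size of the step stays open because compound 3 has only a limit as its starting point: the limit of > 10000 nM in this assay, at which 2 of the 4 values shown sit. Also open is how an amine, a carboxylic acid or a longer chain such as ethoxy would behave at the same place on this core.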